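The compounds below may be only part of what the source reports. "The series", "measured", "known", "first", "only" and "open" are said of these compounds alone.

Among the compounds with values here, in a functional assay on SMMC-7721 cells (Homo sapiens) for cytotoxicity, read by MTT assay, with a stated time of 24 h (on this read-out lower numbers stand for stronger inhibition and higher numbers for weaker inhibition), only two compounds with the same core have been measured so far. Compound 1 (`O=C1/C(=C/c2cccnc2)CN(S(=O)(=O)c2ccc(C(F)(F)F)cc2)C/C1=C\c1ccccc1F`) gives 7900 nM in this test, while compound 2 (`O=C1/C(=C/c2cccnc2)CN(S(=O)(=O)c2ccc(Cl)cc2)C/C1=C\c1ccccc1F`) gives 16100 nM as the higher number of the pair, which marks it as the weaker inhibitor of the two. Compound 3 (`O=C1/C(=C/c2cccnc2)CN(S(=O)(=O)c2ccc(Br)cc2)C/C1=C\c1ccccc1F`) differs from compound 2 in one place (bromo in place of chloro on an aromatic carbon), with bromo in place of chloro on an aromatic carbon, para to a large group. Within the data shown here, the one measured step at this carbon (a 2.0-fold higher number from compound 1 to compound 2 (0.31 log units; beyond the scatter)) replaced trifluoromethyl with chloro and was modest. One modest step is thin evidence, but it gives no reason to expect a large change from swapping one halogen for another, so no step beyond the scatter is expected. The estimated step is small (a 1.2-fold lower number from compound 2 to compound 3 (0.09 log units; within the scatter)). In this assay compound 3 is expected to give 13000 nM (estimated range 6500 nM to 26000 nM).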

Compound 3, half-maximal inhibitory concentration: 9100 nM
Beside the measured number, compound 3's estimate is 1.4-fold (0.15 log units) above it, within the range that was stated.
By their numbers in this assay, from the lowest: compounds 1, 3 and 2 (each within the scatter of the next, the first and the last beyond it).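

Swapping chloro for bromo on this aromatic carbon, para to a large group, gives a 1.8-fold lower number from compound 2 to compound 3 (0.25 log units; within the scatter) in this assay and so cannot be told apart from the measurement scatter. Swapping trifluoromethyl for bromo gives a 1.2-fold higher number from compound 1 to compound 3 (0.06 log units; within the scatter) and also stays within the scatter, so bromo cannot be separated from either earlier group on its own. Within the data shown here, the one step beyond the scatter at this carbon therefore remains the modest 2.0-fold higher number from compound 1 to compound 2 (0.31 log units; beyond the scatter) between the two earlier compounds, and no measurement here explains why these values lie so close together.

On these data alone, whether an amine, a carboxylic acid or a longer chain on this carbon would shift the number much further remains open. Also open, as far as these compounds go, is whether these small steps would hold if the other parts of the shared core were different.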